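Phenyl to 2,4-dichlorophenyl: compound 1 to compound 3

This account rests on a few compounds, and the source may have more. Where it says the series, first, only, none or still open, it means among the compounds named here.

Within the data shown here, in a functional assay on HT-29 cells (Homo sapiens) for inhibition, read by sulforhodamine B assay, with a stated time of 48 h (on this read-out lower numbers stand for stronger inhibition of growth and higher numbers for weaker inhibition of growth), compound 1 `O=C(Cc1csc2nc(-c3ccc(Br)cc3)cn12)N/N=C/c1ccccc1` gives 43700 nM, the higher of the two numbers measured so far. Compound 2 `COc1cccc(OC)c1/C=N/NC(=O)Cc1csc2nc(-c3ccc(Br)cc3)cn12` gives 16200 nM in this assay. Among the measured compounds shown here, only one measured step bears on the change at hand: a 2.7-fold lower number from compound 1 to compound 2 (0.43 log units; beyond the scatter), with 2,6-dimethoxyphenyl in place of phenyl on a carbon with a double bond to nitrogen.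

Compound 3 `O=C(Cc1csc2nc(-c3ccc(Br)cc3)cn12)N/N=C/c1ccc(Cl)cc1Cl` differs from compound 1 at that same place: 2,4-dichlorophenyl in place of phenyl on a carbon with a double bond to nitrogen. For the measured compounds named here, the incoming group is a different one, and no measured compound carries 2,4-dichlorophenyl, so the single step offers only a rough guide. Its size and direction still set the working expectation of a modest move towards a lower number in this assay, though a result within the scatter of compound 1 would not be surprising. The expected step is a 2.2-fold lower number from compound 1 to compound 3 (0.34 log units; beyond the scatter). For compound 3 the estimated value is 20000 nM, with an expected range from 7000 nM to 55000 nM.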

Compound 3, concentration for 50% growth inhibition: 40700 nM
For compound 3 the middle estimate is 2.0-fold (0.31 log units) below the measured one; low and high end bracket the measured number.
By their numbers in this assay, from the lowest: compound 2; then compounds 3 and 1 (each within the scatter of the next).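

In this assay, substitution of the phenyl on a carbon with a double bond to nitrogen does not by itself separate compounds: a 1.1-fold lower number from compound 1 to compound 3 (0.03 log units; within the scatter), so 2,4-dichlorophenyl and phenyl cannot be told apart here. The lower number of compound 2 is therefore not shared by both substituted phenyls shown, since there is a 2.5-fold higher number from compound 2 to compound 3 (0.40 log units; beyond the scatter), and among these compounds only 2,6-dimethoxyphenyl stands apart from phenyl. No measurement is available to explain this difference between 2,6-dimethoxyphenyl and 2,4-dichlorophenyl.

Going by these compounds, with only these three groups at this place, it remains open whether a single methoxy group, a hydroxyl group or a dimethylamino group on the phenyl would give a number like that of compound 2 or one like that of compound 1. On these data alone, the rest of the shared core is identical in all three compounds, so it is also open whether the step from phenyl to 2,6-dimethoxyphenyl would hold with any other group elsewhere on that core.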